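Swapping 4-methylphenyl for 4-fluorophenyl on the butyl compound

The source may report more compounds than this note shows. Statements on the series, on what has been measured and on what is new or still open speak of the compounds shown alone.

Measured so far in a functional assay on MCF7 cells (Homo sapiens) for antiproliferative activity, with a stated time of 5 days; a lower number here means a stronger inhibitor, a higher number a weaker inhibitor:
compound 1 `Cc1ccc(-c2[nH]c3cc(Cl)ccc3c2C=O)cc1` gives 37 nM
compound 2 `Cc1ccc(-c2[nH]c3ccc(C)cc3c2C=O)cc1` gives 165 nM
compound 3 `CCCCc1ccc2[nH]c(-c3ccc(C)cc3)c(C=O)c2c1` gives 54 nM

In this assay compound 3 stands at 54 nM, within the scatter of compound 1, while compound 2 has the highest number of the three at 165 nM. The next compound to be read is compound 4 `CCCCc1ccc2[nH]c(-c3ccc(F)cc3)c(C=O)c2c1`. The change is fluoro in place of methyl on an aromatic carbon, which turns the 4-methylphenyl into a 4-fluorophenyl.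

Among the compounds with values here, the only measured step is a 3.1-fold lower number from compound 2 to compound 3 (0.49 log units; beyond the scatter). It lies elsewhere on the molecule and leaves the 4-methylphenyl untouched, so it gives no direct reading on this swap. All three measured compounds carry the 4-methylphenyl, and the data hold no measured change at this group. No direction can therefore be taken from the series, and no step beyond the scatter is expected in this assay, though a larger move in either direction cannot be excluded. The estimated change is a 1.3-fold higher number from compound 3 to compound 4 (0.11 log units; within the scatter). The expected value for compound 4 is 70 nM, with an estimated range of 25 nM to 200 nM.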

Compound 4, half-maximal inhibitory concentration: 200 nM
Estimate against measurement, compound 4: 2.9-fold (0.46 log units) below, within the range that was stated.
By their numbers in this assay, from the lowest: compounds 1 and 3 (each within the scatter of the next); then compounds 2 and 4 (each within the scatter of the next).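

Notes on the 4-methylphenyl: this is the first measured change at this group, and in this assay the swap to 4-fluorophenyl gives a 3.7-fold higher number from compound 3 to compound 4 (0.57 log units; beyond the scatter). The group on the aromatic carbon para to a large group therefore affects the read-out, and the 4-methylphenyl and the 4-fluorophenyl cannot be treated as interchangeable on the butyl compound, even though the swap exchanges one heavy atom for one heavy atom and leaves the counts of rings, hydrogen-bond donors and hydrogen-bond acceptors as they were. No independent measurement at hand bears on the reason for this step.

The compounds shown hold this swap only on the butyl compound, so it remains open whether the same direction and size would appear with the chlorine of compound 1 or the methyl of compound 2 in place of the butyl arrangement. Also open, going by these compounds, is how this position would read with other groups, such as a methoxy, an amine, a carboxylic acid or a longer chain, and so whether the methyl itself or only the loss of it drives the step.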